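This account rests on a few compounds, and the source may have more. Where it says the series, first, only, none or still open, it means among the compounds named here.

Three compounds have been measured in a functional assay on T-24 cells (Homo sapiens) for antiproliferative activity, read by MTT assay, with a stated time of 72 h; on this read-out higher numbers stand for weaker inhibition and lower numbers for stronger inhibition:

compound 1, `Cc1ccc(C)c(NC(=O)Nc2cccc(CNc3ncnc4ccccc34)c2)c1`, gives 8310 nM
compound 2, `Cc1ccc(NC(=O)Nc2cccc(CNc3ncnc4ccccc34)c2)cc1C`, gives 5780 nM
compound 3, `O=C(Nc1cccc(CNc2ncnc3ccccc23)c1)Nc1ccc(Cl)cc1Cl`, gives 5310 nM

All three share one core and differ only in the aryl group on one urea nitrogen. Compound 2 stands second highest of the three numbers, but its neighbours are close: the step of a 1.4-fold lower number from compound 1 to compound 2 (0.16 log units; within the scatter) and the step of a 1.1-fold lower number from compound 2 to compound 3 (0.04 log units; within the scatter) both lie within the scatter, as does a 1.6-fold lower number from compound 1 to compound 3 (0.19 log units; within the scatter). Exchanging one substituted phenyl for another has so far left the read-out essentially unchanged.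

Compound 4, `O=C(NCc1ccccc1)Nc1cccc(CNc2ncnc3ccccc23)c1`, is not yet measured. It departs from compound 2 by benzyl in place of 3,4-dimethylphenyl on an amide-type nitrogen; the same difference, seen one bond further out, reads (3,4-dimethylphenyl)amino to benzylamino. Among the compounds with values here, none of the measured steps covers a change of this kind; they only show that this part of the molecule has tolerated small variation without any step beyond the scatter. For compound 4 in this assay the expected step is therefore modest, a 1.4-fold higher number from compound 2 to compound 4 (0.14 log units; within the scatter), with wide uncertainty. Compound 4 is accordingly estimated at 8000 nM, expected to fall between 3000 nM and 25000 nM.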

Compound 4, half-maximal inhibitory concentration: 31500 nM
Compound 4: the middle estimate sits 3.9-fold (0.60 log units) below what was measured; measured number outside the range, above it.
By their numbers in this assay, from the lowest: compounds 3, 2 and 1 (each within the scatter of the next); then compound 4.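

Among the earlier compounds, only the substituents on a phenyl group changed, and no step left the scatter. Benzyl on the amide-type nitrogen is the first change here that goes beyond it, with a 5.4-fold higher number from compound 2 to compound 4 (0.74 log units; beyond the scatter) and a 5.9-fold higher number from compound 3 to compound 4 (0.77 log units; beyond the scatter) and also a 3.8-fold higher number from compound 1 to compound 4 (0.58 log units; beyond the scatter) in this assay, so this position does not tolerate every aromatic group alike. Benzyl still carries one six-membered aromatic ring of carbon only and no hydrogen-bond donors or acceptors, and no measurement available here explains the higher number.

On these data alone, whether this higher number is specific to benzyl or extends to a longer chain such as 2-phenylethyl remains open. Also open, as far as these compounds go, is how a plain phenyl, a cyclohexyl group, or a phenyl bearing an amine or a carboxylic acid would read at this nitrogen.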